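Chloro in place of methyl on the phenyl-triazole arm

The source may report more compounds than this note shows. Statements on the series, on what has been measured and on what is new or still open speak of the compounds shown alone.

Compound 1 `Cc1ccccc1-n1nncc1CN1C(=O)C2(C(C#N)=C(N)Oc3c(N)cc4nc5ccccc5nc4c32)c2ccccc21`: 31700 nM
Compound 2 `Cc1ccc(C)c(-n2nncc2CN2C(=O)C3(C(C#N)=C(N)Oc4c(N)cc5nc6ccccc6nc5c43)c3ccccc32)c1`: only a limit, > 50000 nM

In a functional assay on A549 cells (Homo sapiens) for antiproliferative activity, read by MTT assay, with a stated time of 48 h (on this read-out lower numbers stand for stronger inhibition and higher numbers for weaker inhibition), compound 1 gives 31700 nM. Compound 2 returns only an assay limit, > 50000 nM, and so sits at the limit of > 50000 nM in this assay, at which 1 of the 2 values shown sits. Among the measured compounds shown here, the one measured step, an at least 1.5-fold higher number from compound 1 to compound 2 (0.19 log units; that floor lies within the scatter), is the addition of a methyl. Compound 3 `Cc1ccc(Cl)cc1-n1nncc1CN1C(=O)C2(C(C#N)=C(N)Oc3c(N)cc4nc5ccccc5nc4c32)c2ccccc21` differs from compound 2 by chloro in place of methyl on an aromatic carbon. For the measured compounds named here, no measured step covers chloro for methyl, so the expectation rests on compound 2 standing at the limit. Compound 3 is expected near 45000 nM, between 15000 nM and 120000 nM. The expected step is an at least 1.1-fold lower number from compound 2 to compound 3 (0.04 log units; that floor lies within the scatter), within the scatter.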

Compound 3, half-maximal inhibitory concentration: > 50000 nM
Compound 3: only a limit was reported; the forecaster's own chance of this, stated with the estimate: 45%; middle value at least 1.1-fold (0.04 log units) from the limit.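

In this assay, chloro in place of hydrogen gives an at least 1.5-fold higher number from compound 1 to compound 3 (0.19 log units; that floor lies within the scatter), so a second substituent at this position, whether methyl or chloro, has now twice returned a limit rather than a number. The step between compound 2 and compound 3 cannot be read because both stand at the assay limit: the limit of > 50000 nM in this assay, at which 2 of the 3 values shown sit.

Going by these compounds, the true values of compound 2 and compound 3 stay open, so methyl and chloro cannot be ranked here. Also open, on these data alone, is whether an amine or a carboxylic acid at this position would return a number in this assay.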